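Swapping a Morpholine Amide for a Carboxylic Acid

This account rests on a few compounds, and the source may have more. Where it says the series, first, only, none or still open, it means among the compounds named here.

Measured compounds:
- compound 1 `O=C(O)/C=C/c1ccncc1-c1ccc2ccccc2c1`: 5 nM
- compound 2 `Cn1ccc2cc(-c3cnccc3/C=C/C(=O)N3CCOCC3)ccc21`: 247 nM
- compound 3 `O=C(/C=C/c1ccncc1-c1ccc2ccccc2c1)N1CCOCC1`: 60.3 nM

In an assay on a protein complex for inhibition of CDK8/Cyclin C (Homo sapiens), with a stated time of 1 h (a lower number here means a stronger inhibitor, a higher number a weaker inhibitor), compound 1 gives 5 nM, the lowest of the three numbers. Compound 3 gives 60.3 nM and compound 2 gives 247 nM, the highest of the three.

Compound 1 and compound 3 share a core and differ in one place: hydroxy in place of morpholin-4-yl on a carbonyl carbon. This change made a step of a 12-fold lower number from compound 3 to compound 1 (1.08 log units; beyond the scatter) in this assay.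

Compound 4 `Cn1ccc2cc(-c3cnccc3/C=C/C(=O)O)ccc21` has not yet been measured. It is built from compound 2 by the same change: hydroxy in place of morpholin-4-yl on a carbonyl carbon. The two cores, that of compound 2 and that of compound 3, differ from each other, but that difference is not broken down here. The place of the change is described in the same words for both pairs. Among the compounds with values here, the change from compound 2 to compound 4 is the same change as the one from compound 3 to compound 1.

On that basis a step of similar size is expected for compound 4 in this assay, about a 9.9-fold lower number from compound 2 to compound 4 (0.99 log units; beyond the scatter), resting on the step measured for compound 1 a 12-fold lower number from compound 3 to compound 1 (1.08 log units; beyond the scatter). Since the core differs, the outcome is less certain than if the same core were used. The expected value for compound 4 in this assay is 25 nM, with a likely range from 8 nM to 80 nM.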

Compound 4, half-maximal inhibitory concentration: 26.8 nM
Compound 4: the middle estimate sits 1.1-fold (0.03 log units) below what was measured; the measured number falls inside the stated range.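

Replacing morpholin-4-yl with hydroxy on the carbonyl carbon turns a (morpholin-4-yl)carbonyl group into a carboxy group, and in this assay this change gave a 9.2-fold lower number from compound 2 to compound 4 (0.96 log units; beyond the scatter). Set beside the earlier result, the change carried over from one core to the other with a step of matching size, since the gap between the two steps cannot be told apart from ordinary variation in repeated measurements: the same change on two cores in this assay, a 12-fold lower number (1.08 log units; beyond the scatter) from compound 3 to compound 1 and a 9.2-fold lower number (0.96 log units; beyond the scatter) from compound 2 to compound 4, 1.3-fold (0.12 log units) apart, within the scatter of two such steps

Within the data shown here, this is still only two pairs of compounds, so it supports carrying the change between these two cores but does not show that a step of this size would appear on every core, and the numbers alone do not explain why the carboxy compounds give the lower values.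

The compounds shown compare only these two groups on the carbonyl carbon, so it remains open whether a methyl ester, a primary amide or an amide of a smaller amine such as dimethylamine would give a value nearer to the carboxylic acid or to the morpholine amide. On these data alone, it also remains open how a longer chain carrying the same carboxy group would behave in this assay.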